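The source may report more compounds than this note shows. Statements on the series, on what has been measured and on what is new or still open speak of the compounds shown alone.

Measured so far:
compound 1, `COC(=O)c1ccccc1-c1cnc(C(=O)CCCCCCc2ccccc2)o1` — in an assay (Rattus norvegicus) for inhibition of Fatty-acid amide hydrolase 1 (Homo sapiens) (on this read-out lower numbers stand for stronger inhibition and higher numbers for weaker inhibition), compound 1 gives 60 nM
compound 2, `O=C(CCCCCCc1ccccc1)c1ncc(-c2ccc([N+](=O)[O-])cc2)o1` — in this assay compound 2 gives 50 nM

Compound 2 has the lower of the two numbers, yet its gap to compound 1 lies within the usual scatter, so the two cannot be told apart. Compound 3, `NC(=O)c1ccc(-c2cnc(C(=O)CCCCCCc3ccccc3)o2)nc1`, carries the change (5-carbamoylpyridin-2-yl in place of 4-nitrophenyl on an aromatic carbon). For the measured compounds named here, no measured step of this kind is known here, so the size of the change in this assay can only be guessed; a modest move toward stronger inhibition seems plausible. Compound 3 is estimated at 15 nM, between 3 nM and 80 nM, a step of a 3.3-fold lower number from compound 2 to compound 3 (0.52 log units; beyond the scatter).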

Compound 3, inhibition constant: 1.2 nM
Estimate against measurement, compound 3: 13-fold (1.10 log units) above, outside the stated range (below it).
By their numbers in this assay, from the lowest: compound 3; then compounds 2 and 1 (each within the scatter of the next).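

In this assay, 5-carbamoylpyridin-2-yl in place of 4-nitrophenyl on this aromatic carbon gives a 42-fold lower number from compound 2 to compound 3 (1.62 log units; beyond the scatter), so the group at this position can matter greatly. The two groups have the same number of heavy atoms, but the entering one adds a hetero atom to its ring and a hydrogen-bond donor. Nothing measured here explains the gain. Still open, going by these compounds, is which feature carries it: plain pyridin-2-yl and 4-carbamoylphenyl would each keep only one of the two, and a carboxylic acid could replace the amide.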